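Indole for thiophene on a chalcone-like sulfide core

The compounds below may be only part of what the source reports. "The series", "measured", "known", "first", "only" and "open" are said of these compounds alone.

Measured so far:
compound 1 `Cc1ccc(CS/C(=C/c2ccc(C)s2)C(=O)c2ccc(Cl)cc2)cc1` gives 50000 nM
compound 2 `O=C(/C(=C\c1ccc(O)cc1O)Sc1ccc(Br)cc1)c1ccc(Cl)cc1` gives 50000 nM

Compound 1 and compound 2 share a core bearing a chlorophenyl ketone on an alkene carrying a sulfide. In a functional assay on DU-145 cells (Homo sapiens) for inhibition, read by trypan blue exclusion, with a stated time of 96 h (a higher number here means a weaker inhibitor of growth, a lower number a stronger inhibitor of growth), compound 1 gives 50000 nM, and compound 2 gives 50000 nM; the two numbers are level at the digits shown, within the scatter, so neither compound stands apart from the other in this assay. Going by the values given here, no step between measured compounds is available, so the effect of any single change on this core is unknown here.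

Compound 3 `Cc1ccc(CS/C(=C/c2c[nH]c3ccc(Cl)cc23)C(=O)c2ccc(Cl)cc2)cc1` is not yet measured. It differs from compound 1 in one place: 5-chloro-1H-indol-3-yl in place of 5-methylthiophen-2-yl on a double-bonded chain carbon bound to a double-bonded chain carbon. Among the compounds with values here, with no measured step to guide the size, the expectation for this change rests only on the level values of compound 1 and compound 2. A modest improvement in this assay is expected, though a change of no size beyond the scatter is also plausible. Compound 3 is therefore estimated at 25000 nM, with a range from 6000 nM to 50000 nM, and the expected step is a 2.0-fold lower number from compound 1 to compound 3 (0.30 log units; within the scatter).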

Compound 3, concentration for 50% growth inhibition: 1000 nM
The estimate for compound 3 lay 25-fold (1.40 log units) above the measured number; the whole stated range lies above it.
By their numbers in this assay, from the lowest: compound 3; then compounds 1 and 2 (each within the scatter of the next).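

In this assay, the position on a double-bonded chain carbon bound to a double-bonded chain carbon proves able to move the read-out: 5-chloro-1H-indol-3-yl in place of 5-methylthiophen-2-yl gives a 50-fold lower number from compound 1 to compound 3 (1.70 log units; beyond the scatter). Compound 1 and compound 2 stood level and offered no single change, so they could not show that this core responds to any one substitution, whereas this step, beyond the scatter, shows that it can respond strongly to a change at this one place. The entering group differs at once in its heavy atoms, its added six-membered aromatic ring, its chlorine and its hydrogen-bond donor, and no supporting measurement shows which of these features accounts for the step.

The compounds shown leave open whether 1H-indol-3-yl without the chlorine would give a step of similar size, or whether fluorine or a methoxy group could stand in the chlorine's place. They also leave open what a methyl group on the indole nitrogen, in place of its hydrogen, would do on the core of compound 1.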